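Swapping Ethyl for Cyclobutyl on the Amine Nitrogen

The compounds below may be only part of what the source reports. "The series", "measured", "known", "first", "only" and "open" are said of these compounds alone.

In an ADME assay on liver (Homo sapiens) for metabolic stability, read by LC-MS, using microsomes and NADPH (a higher number here means that more of the compound is left, a lower number that less of the compound is left), compound 3 `CCN(Cc1ccc(OCCn2c(=O)ccn(C)c2=O)c(C)c1)C(CC(=O)O)c1ccc(Cl)cc1` gives 46%, the lowest of the three measured numbers and beyond the scatter from the other two. Compound 1 `CCCN(Cc1ccc(OCCN2C(=O)CCC2=O)c(C)c1)[C@@H](CC(=O)O)c1ccc(Cl)cc1` gives 97% and compound 2 `CCN(Cc1ccc(OCCN2C(=O)CCC2=O)c(C)c1)C(CC(=O)O)c1ccc(Cl)cc1` gives 100%, values within the scatter of each other, although these two compounds carry different groups on the amine nitrogen. The next compound, compound 4 `Cc1cc(CN(C2CCC2)C(CC(=O)O)c2ccc(Cl)cc2)ccc1OCCn1c(=O)ccn(C)c1=O`, keeps the rest of compound 3 and changes that nitrogen: cyclobutyl in place of ethyl on an amine nitrogen. For the measured compounds named here, the only measured step, a number 54 percentage points lower from compound 2 to compound 3 (beyond the scatter), is large, but it lies at another place in the molecule and does not test this change. The close values of compound 1 and compound 2 offer only a weak guide, since neither compound has cyclobutyl and both remain near the top of the scale. No step beyond the scatter is therefore expected, and the expected change is a number 4 percentage points lower from compound 3 to compound 4 (within the scatter). The estimate for compound 4 is 42%, with an expected range from 22% to 64%.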

Compound 4, percent of the compound remaining: 20%
Compound 4: the middle estimate sits 22 percentage points above what was measured; measured number below the stated range.
By their numbers in this assay, from the lowest: compound 4; then compound 3; then compounds 1 and 2 (each within the scatter of the next).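

The group on the amine nitrogen matters in this series: in this assay, cyclobutyl in place of ethyl gives a number 26 percentage points lower from compound 3 to compound 4 (beyond the scatter). This is the only step at this position among the compounds shown, so it shows that this nitrogen is a place where a change in the group can alter how much compound is left. It holds for this one pair, which shares the core of compound 3, and no measurement shown explains why less of compound 4 is left.

Open, from the compounds shown here alone, is whether cyclopropyl or isopropyl on this nitrogen would stay closer to ethyl or to cyclobutyl, or whether the result depends on ring size at all. Also open, going by these compounds, is whether cyclobutyl would bring a similar step in compound 2, which has the five-membered ring at the other end of the molecule.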